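A Fluorine Joins the Benzyl Arm of Compound 2

A few compounds are considered here, and "the series" means these few. Any claim that something is new, unique, unknown or untested is made for them only; others in the source may bear on it.

Three compounds have been measured so far in a functional assay on DLD-1 cells (Homo sapiens) for inhibition, read by MTT assay, with a stated time of 72 h; a lower number here means a stronger inhibitor, a higher number a weaker inhibitor:

Compound 1 `COc1ccc(CNCc2c(OC)cc(Oc3cccc(Nc4ccccc4)c3)cc2OC)cc1`: 1910 nM
Compound 2 `COc1cc(Oc2cccc(Nc3ccccc3)c2)cc(OC)c1CNCc1ccccc1`: 5220 nM
Compound 3 `COc1ccc(CCCNCc2c(OC)cc(Oc3ccc(Nc4ccccc4)cc3)cc2OC)cc1`: 4650 nM

Compound 2 gives the highest number of the three. Compound 3 sits nearest to it, and the two values lie within the scatter, so nothing separates them. Compound 1 lies furthest away, beyond the scatter, and the two are linked by a single structural step: a 2.7-fold higher number from compound 1 to compound 2 (0.44 log units; beyond the scatter), the change being a hydrogen in place of a methoxy on an aromatic carbon.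

The next compound, compound 4 `COc1cc(Oc2cccc(Nc3ccccc3)c2)cc(OC)c1CNCc1ccc(F)cc1`, differs from compound 2 in one place: fluoro in place of hydrogen on an aromatic carbon. Among the compounds with values here, no measured step involves a fluoro, so there is no direct precedent. Within the data shown here, the one single-place step known here, from compound 1 to compound 2, concerns a methoxy, a different group, and gives only indirect guidance that a substituent on that benzyl ring can shift the number by a modest amount.

The change from compound 2 to compound 4 is therefore expected to be small, most likely within the scatter or a slight lowering of the number: a 1.3-fold lower number from compound 2 to compound 4 (0.12 log units; within the scatter). Compound 4 is estimated at 4000 nM, with a range from 1800 nM to 9000 nM.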

Compound 4, half-maximal inhibitory concentration: 2650 nM
Compound 4: the middle estimate sits 1.5-fold (0.18 log units) above what was measured; low and high end bracket the measured number.
By their numbers in this assay, from the lowest: compounds 1, 4, 3 and 2 (each within the scatter of the next, the first and the last beyond it).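

In this assay, a 2.0-fold lower number from compound 2 to compound 4 (0.29 log units; within the scatter) is the step for benzyl to 4-fluorobenzyl, so a single fluorine atom at this place, para to a large group, gives no change that can be told apart from the scatter of repeated measurements. Within the data shown here, the fluoro and the methoxy at this place also cannot be separated, as a 1.4-fold higher number from compound 1 to compound 4 (0.14 log units; within the scatter) is their step, whereas a 2.7-fold higher number from compound 1 to compound 2 (0.44 log units; beyond the scatter) is the one step here that clears the scatter, so compound 4 has no firm place on either side of that gap and the result alone does not show that fluoro matters at this place. Nothing measured here offers a reason for these numbers.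

Still open, from the compounds shown here alone, is whether a chloro, a hydroxyl, an amine or a carboxylic acid at this same place would move the number beyond the scatter relative to compound 2. Also open, going by these compounds, is what a longer chain carrying the same 4-fluorophenyl ring would do, set against compound 4.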